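Replacing a methoxy with a hydroxy in compound 3

The source may report more compounds than this note shows. Statements on the series, on what has been measured and on what is new or still open speak of the compounds shown alone.

Three related compounds sharing one core have been tested in a functional assay on L1210 cells (Mus musculus) for antiproliferative activity, read by MTT assay, with a stated time of 72 h; on this read-out lower numbers stand for stronger inhibition and higher numbers for weaker inhibition. Compound 1 `COc1cc(/C(=C/c2ccc(C)cc2)C(C)O)cc(OC)c1OC` gives 33500 nM. Compound 2 `COc1cc(/C(=C/c2ccc(Br)cc2)C(C)O)cc(OC)c1OC` gives > 100000 nM, which is a limit of the assay and not an exact number. Compound 3 `COc1ccc(/C=C(/c2cc(OC)c(OC)c(OC)c2)C(C)O)cc1OC` gives 69000 nM, the higher of the two exact numbers, and its gap to compound 1 lies just beyond the scatter.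

Compound 4 `COc1ccc(/C=C(/c2cc(OC)c(OC)c(OC)c2)C(C)O)cc1O` differs from compound 3 in one place: hydrogen in place of methyl on an oxygen on an aromatic ring. In short, a methoxy becomes a hydroxy. Among the measured compounds shown here, only one measured step offers any guide, and it is a different change, bromo in place of methyl on an aromatic carbon: an at least 2.9-fold higher number from compound 1 to compound 2 (0.47 log units; beyond the scatter). Its size is only a bound, set by the limit of > 100000 nM in this assay, at which 1 of the 3 values shown sits. For the measured compounds named here, it suggests that one small swap can move the number beyond the scatter, but no measured step tests methoxy to hydroxy. With compound 3 at 69000 nM, high among the exact numbers, a modest fall seems more likely than a rise, though with wide uncertainty. The expected change is a 2.3-fold lower number from compound 3 to compound 4 (0.36 log units; beyond the scatter). The estimated value for compound 4 is 30000 nM, with an expected range from 6000 nM to 100000 nM.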

Compound 4, half-maximal inhibitory concentration: 4100 nM
The estimate for compound 4 lay 7.3-fold (0.86 log units) above the measured number; the whole stated range lies above it.
By their numbers in this assay, from the lowest: compound 4; then compound 1; then compound 3. At a limit, above all of these: compound 2.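

In this assay, putting hydrogen in place of methyl on an oxygen on an aromatic ring gives a 17-fold lower number from compound 3 to compound 4 (1.23 log units; beyond the scatter), a large step from one small change. Among the compounds shown here, this place on the shared core therefore has a strong hold on the number, and the step is an exact measured size, whereas the only earlier step, a different swap at a different place, ran upward and has a size known only as a bound. Nothing in the data at hand explains why this methoxy to hydroxy change has so large an effect.

On these data alone, it remains open whether the hydroxy itself is what matters, or whether an amine or a fluoro at the same place would do as much. As far as these compounds go, it is equally open whether an ethoxy there would push the number back up, and whether the other methoxy groups respond to the same swap.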